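A few compounds are considered here, and "the series" means these few. Any claim that something is new, unique, unknown or untested is made for them only; others in the source may bear on it.

Measured in a functional assay on BCG823 cells (Homo sapiens) for inhibition, read by MTT assay, with a stated time of 72 h; on this read-out lower numbers stand for stronger inhibition and higher numbers for weaker inhibition:
compound 1 `CN(C(=O)NC(=O)c1ccc(F)c(F)c1)c1nc(C(F)(F)F)c(C(=O)N/N=C/c2ccccc2C(F)(F)F)s1` — 3.66 ug/mL
compound 2 `CN(C(=O)NC(=O)c1ccc(F)c(F)c1)c1nc(C(F)(F)F)c(C(=O)N/N=C/c2cccc(C(F)(F)F)c2)s1` — 4.46 ug/mL
compound 3 `CN(C(=O)NC(=O)c1ccc(F)c(F)c1)c1nc(C(F)(F)F)c(C(=O)N/N=C/c2ccc([N+](=O)[O-])cc2)s1` — 2.99 ug/mL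

Compound 1 sits second highest of the three numbers. The measured steps of a 1.2-fold higher number from compound 1 to compound 2 (0.09 log units; within the scatter), a 1.2-fold lower number from compound 1 to compound 3 (0.09 log units; within the scatter) and a 1.5-fold lower number from compound 2 to compound 3 (0.17 log units; within the scatter) all lie within the scatter, and all of them change only the aryl group on the carbon with a double bond to nitrogen.

Compound 4 `CN(C(=O)NC(=O)c1c(F)cccc1F)c1nc(C(F)(F)F)c(C(=O)N/N=C/c2ccccc2C(F)(F)F)s1` differs from compound 1 at a different place: 2,6-difluorophenyl in place of 3,4-difluorophenyl on a carbonyl carbon. Among the compounds with values here, no measured step touches the (difluorophenyl)carbonyl group, so no measured step bears directly on this change; the only guidance is that the three compounds sharing this group spread within the scatter of one another. Compound 4 is therefore expected to show a 1.0-fold higher number from compound 1 to compound 4 (0.00 log units; within the scatter), with no direction beyond the scatter. The estimate for compound 4 in this assay is 3.7 ug/mL, range 1.5 ug/mL to 9 ug/mL.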

Compound 4, half-maximal inhibitory concentration: 17 ug/mL
Compound 4: middle estimate off by 4.6-fold (0.66 log units), on the low side, outside the stated range (above it).
By their numbers in this assay, from the lowest: compounds 3, 1 and 2 (each within the scatter of the next); then compound 4.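

Working notes on the series: on the carbonyl carbon, 2,6-difluorophenyl in place of 3,4-difluorophenyl gives in this assay a step of a 4.6-fold higher number from compound 1 to compound 4 (0.67 log units; beyond the scatter) and is the first change in this set to pass the scatter. The two groups hold the same atoms, so the fluorine pattern on this ring alone separates the pair. No available data explain this step.

Open, going by these compounds, is whether the step holds with 4-nitrophenyl or 3-(trifluoromethyl)phenyl on the carbon with a double bond to nitrogen. Also open, on these data alone, is how unsubstituted phenyl or a pyridyl ring would read on the carbonyl carbon.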